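Removing the sulfonyl group from compound 2

The source may hold more compounds than are shown below. What is called first, only, known or untested is meant among the compounds shown, and "the series" means these compounds.

In an ADME assay on Chem1 cells (Homo sapiens) for cytotoxicity (on this read-out higher numbers stand for lower toxicity in this test and lower numbers for higher toxicity in this test), compound 1 `NCCCCN(C[C@H]1CN(S(=O)(=O)c2cc3ccccc3s2)CCN1)[C@H]1CCCc2cccnc21` gives > 10 uM as a limit of the assay. Compound 2 `NCCCCN(C[C@H]1CN(S(=O)(=O)c2ccc(Cl)cc2)CCN1)[C@H]1CCCc2cccnc21` gives > 10 uM which is likewise a limit. Among the measured compounds shown here, the one measured step is a step that the two limits leave unreadable from compound 1 to compound 2 with 4-chlorophenyl in place of 1-benzothiophen-2-yl on a sulfonyl sulfur, and it offers no size to carry forward. For the measured compounds named here, compound 3 `NCCCCN(C[C@H]1CNCCN1)[C@H]1CCCc2cccnc21` has hydrogen in place of (4-chlorophenyl)sulfonyl on an amine nitrogen in a ring and no measured step covers this change. Compound 2 at > 10 uM is only a limit, and from it no step beyond the scatter is expected in this assay in either direction. The expected result is a step that the limit leaves unreadable from compound 2 to compound 3 by estimate only. For compound 3 the estimate is 15 uM with an expected range of 6 uM to 50 uM in this read-out.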

Compound 3, half-maximal toxic concentration: > 10 uM
Compound 3 ended at the assay's limit; the forecaster's own chance of this, stated with the estimate: 85%; the middle value does not contradict the limit.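

No step can be read from compound 2 to compound 3, as both stand only at a limit in this assay: the limit of > 10 uM in this assay, at which 3 of the 3 values shown sit. The compounds shown leave open what true toxic concentration lies behind that limit for compound 1, compound 2 or compound 3.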